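A few compounds are considered here, and "the series" means these few. Any claim that something is new, unique, unknown or untested is made for them only; others in the source may bear on it.

Compound 1 `O=C(CSc1nc2ccccc2[nH]1)Nc1ccc2nc(NC(=O)c3ccc(C(F)(F)F)cc3)sc2c1` is one of two compounds with a number in a functional assay on HCT-116 cells (Homo sapiens) for antiproliferative activity, read by MTT assay, with a stated time of 72 h (a lower number here means a stronger inhibitor, a higher number a weaker inhibitor), where compound 1 gives 3760 nM. The other, compound 2 `O=C(CSc1cccc(O)c1)Nc1ccc2nc(NC(=O)c3cccs3)sc2c1`, gives 7020 nM in this assay; compound 1 has the lower of the two numbers, but the gap to compound 2 lies within the usual scatter, so the two cannot be placed in order. Compound 3 `O=C(CSC1CCCCC1)Nc1ccc2nc(NC(=O)c3ccc(C(F)(F)F)cc3)sc2c1` has not yet been measured. It differs from compound 1 in one place, (cyclohexyl in place of 1H-benzimidazol-2-yl on a sulfur). Among the measured compounds shown here, no measured pair shows what such a change does here, so any expectation rests on compound 1 alone, and the step expected from compound 1 to compound 3 is a 1.5-fold higher number from compound 1 to compound 3 (0.17 log units; within the scatter), a small weakening that may well stay within the scatter. For compound 3 the estimate in this assay is 5500 nM, with a range from 1800 nM to 17000 nM.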

Compound 3, half-maximal inhibitory concentration: 21000 nM
Compound 3: middle estimate off by 3.8-fold (0.58 log units), on the low side, and the stated range ends below it.
By their numbers in this assay, from the lowest: compounds 1 and 2 (each within the scatter of the next); then compound 3.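

The sulfur position turns out to be sensitive to what it carries: in this assay, cyclohexyl in place of 1H-benzimidazol-2-yl gives a 5.6-fold higher number from compound 1 to compound 3 (0.75 log units; beyond the scatter), a weakening beyond the scatter. The change replaces an aromatic five-membered ring and an aromatic six-membered ring, together holding a hydrogen-bond donor and acceptor, with one non-aromatic carbon ring holding neither, so in this pair a ring on the sulfur does not by itself keep the number near that of compound 1. No measurement at hand tells which of these differences accounts for the step.

This single pair cannot separate the loss of aromatic rings from the loss of the ring nitrogens. From the compounds shown here alone, a plain phenyl or a piperidinyl ring on this sulfur, with the rest of compound 1 kept, could pull those two apart, and what either would give remains open.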